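This account rests on a few compounds, and the source may have more. Where it says the series, first, only, none or still open, it means among the compounds named here.

Compound 3 `COc1cc(C(=O)N2CC[C@H](O)[C@@H](C)C2)cc2nc(NCc3cccc(Cl)c3)oc12` gives 120 nM in an assay on isolated protein for inhibition of thyroid hormone receptor beta (Homo sapiens), read by fluorescence, with a stated time of 30 min (on this read-out lower numbers stand for stronger inhibition and higher numbers for weaker inhibition), the highest number among the three measured, whereas compound 1 `COc1cc(C(=O)N2CCC(C)(C)C2)cc2nc(NCc3cccc(Cl)c3)oc12` gives 40 nM and compound 2 `COc1cc(C(=O)N2CC[C@@H](O)C(C)(C)C2)cc2nc(NCc3cccc(Cl)c3)oc12` gives 35 nM. Compound 4 `CCC1CC(O)C(C)CN1C(=O)c1cc(OC)c2oc(NCc3cccc(Cl)c3)nc2c1` differs from compound 3 in one place: 2-ethyl-4-hydroxy-5-methylpiperidin-1-yl in place of 4-hydroxy-3-methylpiperidin-1-yl on a carbonyl carbon. Going by the values given here, two measured steps bear on this change. Taking one methyl away from the ring on the carbonyl carbon gave a 3.4-fold higher number from compound 2 to compound 3 (0.54 log units; beyond the scatter), and the change from a five-membered ring with two methyls gave a 3.0-fold higher number from compound 1 to compound 3 (0.48 log units; beyond the scatter), so in this small set more alkyl on that ring has gone with lower numbers. An added ethyl is therefore expected to lower the number modestly, giving a 1.7-fold lower number from compound 3 to compound 4 (0.23 log units; within the scatter). Compound 4 is estimated at 70 nM, within a range from 25 nM to 200 nM.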

Compound 4, half-maximal inhibitory concentration: 13 nM
For compound 4 the middle estimate is 5.4-fold (0.73 log units) above the measured one, and the stated range ends above it.
By their numbers in this assay, from the lowest: compound 4; then compounds 2 and 1 (each within the scatter of the next); then compound 3.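

Putting the 2-ethyl-4-hydroxy-5-methylpiperidin-1-yl group on the carbonyl carbon gives a 9.2-fold lower number from compound 3 to compound 4 (0.97 log units; beyond the scatter) in this assay and the largest step seen at this place. The same group also gives a 2.7-fold lower number from compound 2 to compound 4 (0.43 log units; beyond the scatter) and a 3.1-fold lower number from compound 1 to compound 4 (0.49 log units; beyond the scatter) and so compound 4 has the lowest number of the four, which shows that this place accepts a larger ring substituent. Nothing shown explains the gain.

Compound 4 is drawn without defined stereocentres, so which spatial form accounts for its value stays open. From the compounds shown here alone, whether a propyl chain in place of the ethyl, or an amine in place of the hydroxy, would keep the number this low is also open.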